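The source may report more compounds than this note shows. Statements on the series, on what has been measured and on what is new or still open speak of the compounds shown alone.

Measured compounds:
- compound 1 `Cc1ccccc1Cn1c(CN2CCN(C(=O)C3CC3)CC2)nc2ccccc21`: 29.1%
- compound 2 `O=C(C1CC1)N1CCN(Cc2nc3ccccc3n2Cc2ccc(C(F)(F)F)cc2)CC1`: 37%
- compound 3 `O=C(C1CC1)N1CCN(Cc2nc3ccccc3n2Cc2ccccc2)CC1`: 23.9%

In an assay on isolated protein for inhibition of aldehyde dehydrogenase 1A1 (Homo sapiens), read by spectrophotometry, tested at 10 uM (on this read-out lower numbers stand for less inhibition and higher numbers for more inhibition at the one concentration tested (going by the name of the read-out)), compound 3 gives the lowest of the three numbers. Compound 1 lies close to it, the step of a number 5.2 percentage points lower from compound 1 to compound 3 (within the scatter) being within the scatter, while compound 2 stands further off, the step of a number 13.1 percentage points lower from compound 2 to compound 3 (beyond the scatter) being beyond it.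

Compound 4 `O=C(C1CC1)N1CCN(Cc2nc3ccccc3n2Cc2ccc(Cl)cc2)CC1` has not yet been measured. It differs from compound 3 in one place: chloro in place of hydrogen on an aromatic carbon.

Within the data shown here, the step that bears on this change is the one from compound 2 to compound 3, where trifluoromethyl gave way to hydrogen on the same aromatic carbon and the number fell, a number 13.1 percentage points lower from compound 2 to compound 3 (beyond the scatter). The step of a number 5.2 percentage points lower from compound 1 to compound 3 (within the scatter) concerns a methyl elsewhere on the ring and was within the scatter, so it says little here. Restoring a group at the position once held by trifluoromethyl is therefore expected to raise the number, though chloro is not trifluoromethyl, so the step is expected to be smaller and only modest: a number 8.1 percentage points higher from compound 3 to compound 4 (within the scatter). Compound 4 is thus estimated at 32%, in a range of 22% to 42%.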

Compound 4, a percentage reported as inhibition, at one concentration (the size of the read-out at that concentration, not a potency): 56.6%
For compound 4 the middle estimate is 24.6 percentage points below the measured one, and the stated range ends below it.
By their numbers in this assay, from the lowest: compounds 3, 1 and 2 (each within the scatter of the next, the first and the last beyond it); then compound 4.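

In this assay, among these compounds, 4-chlorobenzyl in place of benzyl gives a number 32.7 percentage points higher from compound 3 to compound 4 (beyond the scatter) and so shows that a single chlorine on this aromatic carbon, para to a large group, can move the number much further than the earlier compounds showed. The step with a number 19.6 percentage points higher from compound 2 to compound 4 (beyond the scatter) shows that chloro and trifluoromethyl are not interchangeable at this carbon, and that the gain seen with trifluoromethyl did not mark the limit for the position. With a number 27.5 percentage points higher from compound 1 to compound 4 (beyond the scatter) as well, compound 4 stands apart from all three earlier compounds, each step beyond the scatter.

On these data alone, whether bromo, fluoro, methoxy or an amine on this carbon would match chloro remains open, as does the effect of chloro on the other carbons of the ring. No measurement at hand accounts for the rise seen with chloro.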